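This account rests on a few compounds, and the source may have more. Where it says the series, first, only, none or still open, it means among the compounds named here.

Measured in a functional assay on MT4 cells (Homo sapiens) for cytotoxicity, read by MTT assay, with a stated time of 5 days; on this read-out higher numbers stand for lower toxicity in this test and lower numbers for higher toxicity in this test:

Compound 1 `N#Cc1ccc(Nc2nccc(Oc3ccc(-c4ccc(C#N)cc4)cc3C(F)(F)F)n2)cc1`: > 273000 nM
Compound 2 `COc1cc(Oc2ccnc(Nc3ccc(C#N)cc3)n2)ccc1-c1ccc(C#N)cc1`: > 298000 nM

Neither entry is an exact reading. In this assay, compound 1 stands at > 273000 nM, which is a limit of the assay and not a number. Compound 2 gives > 298000 nM, which is also a limit. Among the measured compounds shown here, these two results therefore offer no measured step to serve as a guide.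

Compound 3 `N#Cc1ccc(Nc2nccc(Oc3ccc(-c4ccc(C#N)cc4)cc3F)n2)cc1` keeps the structure of compound 1 except at one place: fluoro in place of trifluoromethyl on an aromatic carbon.

The only direct starting point for this change is compound 1, with its limit of > 273000 nM. No shift beyond the usual scatter is expected in this assay, in either direction, and another limit is the most likely report. The expected size of the change is a step that the limit leaves unreadable from compound 1 to compound 3. For compound 3, the estimated value is 300000 nM, with an expected range from 100000 nM to 350000 nM.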

Compound 3, half-maximal cytotoxic concentration: > 307000 nM
Compound 3: no number, only a limit; the forecaster's own chance of this, stated with the estimate: 75%; at least 1.0-fold (0.01 log units) between middle value and limit.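

In this assay compound 3 gives > 307000 nM, which is a limit of the assay and not a number. Among the compounds shown here, compound 1 also stands at a limit, so no step between compound 1 and compound 3 can be read. The compounds shown leave open the concentration at which either would harm these cells, and whether fluoro in place of trifluoromethyl changes it.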